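The source may report more compounds than this note shows. Statements on the series, on what has been measured and on what is new or still open speak of the compounds shown alone.

In an ADME assay on L02 cells (Homo sapiens) for cytotoxicity, read by MTT assay, with a stated time of 24 h (on this read-out higher numbers stand for weaker inhibition and lower numbers for stronger inhibition), compound 1 (`CN1C/C(=C\c2cccnc2)C(=O)/C(=C/c2ccccc2F)C1`) gives 15900 nM and compound 2 (`O=C1/C(=C/c2cccnc2)CNC/C1=C\c1ccccc1F`) gives 15900 nM. Compound 3 (`O=C1/C(=C/c2cccnc2)CN(S(=O)(=O)c2ccc(F)cc2)C/C1=C\c1ccccc1F`) gives 15600 nM, within the scatter of both. Compound 4 (`CC(=O)Nc1ccc(S(=O)(=O)N2C/C(=C\c3cccnc3)C(=O)/C(=C/c3ccccc3F)C2)cc1`) differs from compound 3 as follows: acetamido in place of fluoro on an aromatic carbon. This is acetamido in place of fluoro on an aromatic carbon, para to a large group. The measured steps all concern the ring amine nitrogen: no change at the digits printed from compound 1 to compound 2 (within the scatter) and a 1.0-fold lower number from compound 1 to compound 3 (0.01 log units; within the scatter). None measures a change on the aromatic ring itself, so the evidence is indirect. No step beyond the scatter is expected in this assay because of a 1.0-fold lower number from compound 2 to compound 3 (0.01 log units; within the scatter), the step that adds the sulfonyl group of compound 3. The estimated value for compound 4 is 15000 nM, with an expected range of 7500 nM to 30000 nM.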

Compound 4, half-maximal inhibitory concentration: 15600 nM
For compound 4 the middle estimate is 1.0-fold (0.02 log units) below the measured one, and the stated range covers the measured number.
By their numbers in this assay, from the lowest: compounds 3, 4, 1 and 2 (each within the scatter of the next).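

On the aromatic ring of the sulfonyl group, acetamido in place of fluoro, para to a large group, gives no change at the digits printed from compound 3 to compound 4 (within the scatter) in this assay. Earlier steps concerned only the ring amine nitrogen; this one shows that, in this assay, 4-fluorophenyl can give way to 4-acetamidophenyl, a group with more heavy atoms, without a step beyond the scatter. No measured evidence accounts for this result. As far as these compounds go, whether an amine, a carboxylic acid or a longer chain at this position would also stay within the scatter remains open.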